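Opening the Amine Ring on a Shared Ester Core

This account rests on a few compounds, and the source may have more. Where it says the series, first, only, none or still open, it means among the compounds named here.

Measured in an ADME assay on HEK-293T cells (Homo sapiens) for cytotoxicity, read by MTT assay, with a stated time of 48 h; on this read-out lower numbers stand for higher toxicity in this test and higher numbers for lower toxicity in this test:
compound 1, `CC1(C)[C@H]2CC[C@]1(C)[C@H](OC(=O)CN1CCCCC1)C2`: 141000 nM
compound 2, `CC1(C)[C@H]2CC[C@]1(C)[C@H](OC(=O)CCCN1CCCCCC1)C2`: 62200 nM
compound 3, `CN(C)CCCC(=O)O[C@@H]1C[C@@H]2CC[C@@]1(C)C2(C)C`: 101000 nM

Compound 1 gives the highest of the three numbers. Its nearest neighbour is compound 3, with a 1.4-fold lower number from compound 1 to compound 3 (0.14 log units; within the scatter); the furthest is compound 2, whose value lies lower by a gap beyond the scatter.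

Compound 4, `CCN(CC)CCCC(=O)O[C@@H]1C[C@@H]2CC[C@@]1(C)C2(C)C`, is not yet measured. It differs from compound 1 in one place: 2-(diethylamino)ethyl in place of piperidin-1-yl on a saturated chain carbon bound to a carbonyl carbon. Among the measured compounds shown here, two measured steps bear on this. The first is a 1.4-fold lower number from compound 1 to compound 3 (0.14 log units; within the scatter), the same kind of exchange at the same place, with the open chain one carbon shorter on each arm. The second is a 1.6-fold higher number from compound 2 to compound 3 (0.21 log units; within the scatter), a ring amine giving way to an open-chain amine further along the chain. Both steps stayed within the scatter, so for compound 4 the expectation is no step beyond the scatter in this assay, that is a 1.2-fold lower number from compound 1 to compound 4 (0.09 log units; within the scatter). Compound 4 is therefore estimated at 115000 nM, with a range from 55000 nM to 240000 nM.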

Compound 4, half-maximal cytotoxic concentration: 166000 nM
Beside the measured number, compound 4's estimate is 1.4-fold (0.16 log units) below it; the measured number falls inside the stated range.
By their numbers in this assay, from the lowest: compounds 2, 3, 1 and 4 (each within the scatter of the next, the first and the last beyond it).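

In this assay, 2-(diethylamino)ethyl in place of piperidin-1-yl on a saturated chain carbon bound to a carbonyl carbon gives a 1.2-fold higher number from compound 1 to compound 4 (0.07 log units; within the scatter) and so adds a second open-chain amine at this place that stays within the scatter of the ring compound. Diethylamino in place of dimethylamino gives a 1.6-fold higher number from compound 3 to compound 4 (0.22 log units; within the scatter) and leaves the read-out within the scatter as well, whereas diethylamino in place of azepan-1-yl gives a 2.7-fold higher number from compound 2 to compound 4 (0.43 log units; beyond the scatter) and is the only one of these steps to pass beyond it. Nothing shown speaks to why the numbers fall this way.

Still open, as far as these compounds go, is whether a morpholine or piperazine ring at this place would stay within the scatter of compound 1. The same question stands for a primary amine or a dipropylamino group on the chain.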